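A few compounds are considered here, and "the series" means these few. Any claim that something is new, unique, unknown or untested is made for them only; others in the source may bear on it.

Working notes on a small set of purine-type benzyl compounds, all tested in a functional assay on M14 cells (Homo sapiens) for cytotoxicity, read by sulforhodamine B assay, with a stated time of 48 h; a higher number here means a weaker inhibitor of growth, a lower number a stronger inhibitor of growth.

Compound 1 `ClCc1cccc(Cn2cnc3ncnc(Cl)c32)c1` gives 3090 nM in this assay. Compound 2 `ClCc1ccccc1Cn1cnc2ncnc(Cl)c21` gives 1900 nM in this assay, and compound 3 `ClCc1ccc(Cn2cnc3c(Cl)nc(Cl)nc32)cc1` gives 10700 nM in this assay. On these three numbers compound 1 stands second highest; its nearest neighbour is compound 2, which lies within the scatter of it, while compound 3 lies beyond the scatter with a higher number. No two of these three differ in only one place, so none of the gaps can be tied to a single structural change.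

Compound 4 `ClCc1cccc(Cn2cnc3nc(Cl)nc(Cl)c32)c1` has not yet been measured. Its difference from compound 1 is chloro in place of hydrogen on an aromatic carbon, between two ring nitrogen atoms, meta to a chloro group. Compound 3 carries the same pair of chloro groups on the core, yet it also differs from compound 1 in where the chloromethyl sits on the benzyl ring, so compound 3 offers only a loose hint. A modest move toward a higher number, or none beyond the scatter, is expected, which is what the step from compound 1 to compound 4 in this assay of a 1.6-fold higher number from compound 1 to compound 4 (0.21 log units; within the scatter) means. For compound 4 the estimate is 5000 nM, with a range from 2000 nM to 15000 nM.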

Compound 4, concentration for 50% growth inhibition: 1380 nM
Compound 4: the middle estimate sits 3.6-fold (0.56 log units) above what was measured; the whole stated range lies above it.
By their numbers in this assay, from the lowest: compounds 4, 2 and 1 (each within the scatter of the next, the first and the last beyond it); then compound 3.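

In this assay, among the compounds shown here, chloro in place of hydrogen on an aromatic carbon, between two ring nitrogen atoms, gives the first step that can be tied to one structural change: a 2.2-fold lower number from compound 1 to compound 4 (0.35 log units; beyond the scatter), a modest move toward stronger inhibition of growth. The core of compound 1 therefore takes a chloro group at this position with no loss in this assay, and with a small gain. Nothing at hand gives a reason for this gain.

This rests on a single pair, so it is not known whether the step holds with the chloromethyl group elsewhere on the benzyl ring. On these data alone, it also remains open whether the gain is particular to chloro or would also appear with an amine, a methoxy group or a methyl group on the same carbon.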